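The source may hold more compounds than are shown below. What is called first, only, known or untested is meant among the compounds shown, and "the series" means these compounds.

In a functional assay on HeLa cells (Homo sapiens) for antiproliferative activity, read by CCK-8 assay, with a stated time of 48 h (on this read-out higher numbers stand for weaker inhibition and lower numbers for stronger inhibition), compound 1 `COc1ccc(/C=C\c2cc(OC)c(OC)c(OC)c2)cc1OCc1ccc(C=O)cc1` gives 4800 nM. Compound 2 `COc1ccc(/C=C\c2cc(OC)c(OC)c(OC)c2)cc1OCc1ccc(CN2C[C@H](O)C[C@@H]2C(=O)O)cc1` reads > 10000 nM, which is a limit of the assay and not a number. Compound 3 `COc1ccc(/C=C\c2cc(OC)c(OC)c(OC)c2)cc1OCc1ccc(CN2CCCC[C@H]2C(=O)O)cc1` reads > 10000 nM, again a limit and not a number. This places compound 3 at the limit of > 10000 nM in this assay, at which 2 of the 3 values shown sit, so its true value is not known.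

Exchanging the formyl group of compound 1 for (2-carboxy-4-hydroxypyrrolidin-1-yl)methyl gives an at least 2.0-fold higher number from compound 1 to compound 2 (0.31 log units; beyond the scatter). Exchanging it for (2-carboxypiperidin-1-yl)methyl gives an at least 2.0-fold higher number from compound 1 to compound 3 (0.31 log units; beyond the scatter). Comparing the two carboxy-bearing groups yields only a step that the two limits leave unreadable from compound 2 to compound 3.

Compound 4 `COc1ccc(/C=C\c2cc(OC)c(OC)c(OC)c2)cc1OCc1ccc(CNCCO)cc1` keeps the shared core and differs from compound 3 by (2-hydroxyethyl)amino in place of 2-carboxypiperidin-1-yl on a saturated chain carbon bound to an aromatic carbon. In words, (2-hydroxyethyl)amino stands in place of 2-carboxypiperidin-1-yl on a saturated chain carbon bound to an aromatic carbon, and the new group has no ring.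

Within the data shown here, no measured step covers this exchange directly. The closest guide is that both carboxy-bearing compounds sit at the limit. Compound 1, which has no carboxy group, gives 4800 nM. A modest move towards lower numbers in this assay therefore seems likely, though with real uncertainty. The estimated change is an at least 1.6-fold lower number from compound 3 to compound 4 (0.22 log units; that floor lies within the scatter). For compound 4 the expected value is 6000 nM, with an estimated range of 1500 nM to 20000 nM.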

Compound 4, half-maximal inhibitory concentration: 4400 nM
The estimate for compound 4 lay 1.4-fold (0.13 log units) above the measured number; measured number inside the range.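

Among these compounds, compound 2 and compound 3, the only earlier compounds with a nitrogen-bearing group at this place, both stand at a limit and not at a number: the limit of > 10000 nM in this assay, at which 2 of the 4 values shown sit. In this assay, the open chain (2-hydroxyethyl)amino on this saturated chain carbon bound to an aromatic carbon gives an at least 2.2-fold lower number from compound 3 to compound 4 (0.35 log units; beyond the scatter) and an at least 2.2-fold lower number from compound 2 to compound 4 (0.35 log units; beyond the scatter), so a nitrogen-bearing group here does not by itself put a compound at the limit. Exchanging the formyl group for ((2-hydroxyethyl)amino)methyl gives a 1.1-fold lower number from compound 1 to compound 4 (0.04 log units; within the scatter), so these two groups cannot be told apart in this read-out.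

The compounds shown leave open whether the carboxylic acid or the ring goes with the limit, since both groups at the limit carry the two together, and a plain piperidin-1-yl group or the carboxylic acid on an open chain, as in (carboxymethyl)amino, would separate them. Also open, as far as these compounds go, is how much the chain itself matters, as a longer chain such as (3-hydroxypropyl)amino or an ethylamino group without the hydroxyl would show.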